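This account rests on a few compounds, and the source may have more. Where it says the series, first, only, none or still open, it means among the compounds named here.

Of the compounds shown here, three have been measured in an ADME assay on Caco-2 cells (Homo sapiens) for permeability, in the apical to basolateral direction; a lower number here means that the compound crosses the layer more slowly, a higher number that the compound crosses the layer faster. Compound 1 `Cn1cncc1CN1CC(N(CC2CCN(C(=O)CC(C)(C)C)CC2)S(=O)(=O)c2ccccn2)Cc2cc(C#N)ccc21` gives 0.5 10^-6 cm/s. Compound 2 `CCS(=O)(=O)N1CCC(CN(C2Cc3cc(C#N)ccc3N(Cc3cncn3C)C2)S(=O)(=O)c2ccccn2)CC1` gives 0.1 10^-6 cm/s, and compound 3 `Cn1cnc(S(=O)(=O)N(Cc2cccc(-n3cccc3)c2)C2Cc3cc(C#N)ccc3N(Cc3cncn3C)C2)c1` gives 0.2 10^-6 cm/s. Compound 2 therefore holds the lowest of the three numbers in this assay, though its gap to compound 3 lies within the scatter, while its gap to compound 1 lies beyond it.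

The step now followed leads from compound 2 to compound 4 `CC(C)C(=O)N1CCC(CN(C2Cc3cc(C#N)ccc3N(Cc3cncn3C)C2)S(=O)(=O)c2ccccn2)CC1`, with the change (isopropylcarbonyl in place of ethylsulfonyl on an amine nitrogen in a ring). Within the data shown here, one measured step bears on this: a 5.0-fold lower number from compound 1 to compound 2 (0.70 log units; beyond the scatter), which runs from a carbonyl group to a sulfonyl group on the same ring nitrogen. The change to compound 4 runs the opposite way, back to a carbonyl group, though isopropylcarbonyl is not neopentylcarbonyl, so the step is expected to be smaller than a full reversal. In this assay compound 4 is thus expected to give a higher number, with an estimated step of a 3.0-fold higher number from compound 2 to compound 4 (0.48 log units; beyond the scatter). The estimate for compound 4 is 0.3 10^-6 cm/s, expected to fall between 0.12 10^-6 cm/s and 0.7 10^-6 cm/s.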

Compound 4, apparent permeability: 0.5 10^-6 cm/s
Compound 4: the middle estimate sits 1.7-fold (0.22 log units) below what was measured, and the stated range covers the measured number.
By their numbers in this assay, from the lowest: compounds 2 and 3 (each within the scatter of the next); then compounds 1 and 4 (each within the scatter of the next).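

In this assay, the swap between carbonyl and sulfonyl on this ring nitrogen now reads in both directions: ethylsulfonyl brings a 5.0-fold lower number from compound 1 to compound 2 (0.70 log units; beyond the scatter), and isopropylcarbonyl brings a 5.0-fold higher number from compound 2 to compound 4 (0.70 log units; beyond the scatter). Among the two carbonyl compounds, the group on the carbonyl carbon makes no visible difference, since isopropyl in place of neopentyl gives no change at the digits printed from compound 1 to compound 4 (within the scatter). Nothing at hand offers a reason for the gap between the sulfonyl compound and the two carbonyl compounds.

As far as these compounds go, with only ethylsulfonyl on the sulfonyl side, it remains open whether a phenylsulfonyl group on this nitrogen would stay as low as compound 2. From the compounds shown here alone, it is also open how the number would respond to a urea at this nitrogen, or to an amine or a carboxylic acid on the chain beyond the carbonyl.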